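From dichlorophenyl to difluorophenyl on the carbonyl carbon

The source may report more compounds than this note shows. Statements on the series, on what has been measured and on what is new or still open speak of the compounds shown alone.

Compound 1 `COc1cc(-c2cc(/C=C/C(=O)c3ccc(Cl)c(Cl)c3)[nH]n2)cc(OC)c1OC`: 56%
Compound 2 `COc1ccc(-c2cc(/C=C/C(=O)c3ccc(N)cc3)[nH]n2)cc1`: -16%

Of the compounds shown here, two have been measured in a functional assay on SN12C cells (Homo sapiens) for cytotoxicity, read by sulforhodamine B assay, with a stated time of 48 h, tested at 10 uM; a higher number here means a weaker effect of the compound at the concentration tested, a lower number a stronger effect. Compound 1 gives 56%, the highest number of the two; compound 2 gives -16%, and the gap between them is beyond the scatter. Going by the values given here, compound 1 and compound 2 differ in more than one place, so the pair shows only that the two values sit far apart.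

Compound 3 `COc1cc(-c2cc(/C=C/C(=O)c3ccc(F)c(F)c3)[nH]n2)cc(OC)c1OC` has not yet been measured. It arises from compound 1 by one change: 3,4-difluorophenyl in place of 3,4-dichlorophenyl on a carbonyl carbon. Among the compounds with values here, no measured pair shows a comparable step, so there is no direct guide to its size or direction. Compound 3 is therefore expected to stay near compound 1, with the step of a number 2 percentage points higher from compound 1 to compound 3 (within the scatter) estimated as none beyond the scatter. For compound 3 the estimated value is 58%, with a range from 32% to 84%.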

Compound 3, a percentage reported as activity, at one concentration (the size of the read-out at that concentration, not a potency): 15%
Compound 3: the middle estimate sits 43 percentage points above what was measured; the measured number lies below the stated range.
By their numbers in this assay, from the lowest: compound 2; then compound 3; then compound 1.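

In this assay, 3,4-difluorophenyl in place of 3,4-dichlorophenyl on a carbonyl carbon gives a number 41 percentage points lower from compound 1 to compound 3 (beyond the scatter), so this position responds strongly to the choice of halogen, in the direction of a stronger effect at the concentration tested. The earlier pair differed in more than one place, whereas here the two groups match in heavy-atom count and ring and differ only in chlorine versus fluorine, which ties a large shift to this single site. Nothing measured here accounts for the size of that shift.

As far as these compounds go, whether the same exchange would act alike on the core of compound 2 remains open. Also open, from the compounds shown here alone, is how a nitrile or a carboxylic acid on this ring would compare with the two halogen pairs.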